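Benzyloxy on the Pendant Ring of a Bis-Chalcone Core

A few compounds are considered here, and "the series" means these few. Any claim that something is new, unique, unknown or untested is made for them only; others in the source may bear on it.

Compound 1, `Cc1cc(O)c(C(=O)/C=C/c2ccc(OCc3ccccc3)cc2)c(-c2ccccc2)c1C(=O)/C=C/c1ccc(OCc2ccccc2)cc1`, gives 30000 nM. Compound 2, `COc1ccc(/C=C/C(=O)c2c(C)cc(O)c(C(=O)/C=C/c3ccc(OC)c(OC)c3)c2-c2ccccc2)cc1OC`, gives "not active" (no number reported). Compound 3, `Cc1cc(O)c(C(=O)/C=C/c2ccc(OCc3ccccc3)cc2)c(-c2ccc(OCc3ccccc3)cc2)c1C(=O)/C=C/c1ccc(OCc2ccccc2)cc1`, gives 30000 nM.

These three compounds were tested in an ADME assay on HEK293 cells (Homo sapiens) for cytotoxicity, read by MTT assay, with a stated time of 24 h; a higher number here means a weaker inhibitor, a lower number a stronger inhibitor. Compound 1 and compound 3 share a core and differ only by benzyloxy in place of hydrogen on an aromatic carbon. The step of no change at the digits printed from compound 1 to compound 3 (within the scatter) shows that this change left the read-out where it was. Compound 2 carries a different core; the difference between the two cores is not broken down here. In this assay compound 2 gives "not active" (no number reported), which is a statement of no measurable effect rather than a number.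

Compound 4, `COc1ccc(/C=C/C(=O)c2c(C)cc(O)c(C(=O)/C=C/c3ccc(OC)c(OC)c3)c2-c2ccc(OCc3ccccc3)cc2)cc1OC`, has not yet been measured. It stands to compound 2 as compound 3 stands to compound 1: the difference is benzyloxy in place of hydrogen on an aromatic carbon, the same kind of change as that from compound 1 to compound 3, made at a place described in the same words. The expectation for compound 4 in this assay rests on two points. First, the step of no change at the digits printed from compound 1 to compound 3 (within the scatter) shows no movement when this change is made on the related core. Second, compound 2 gives "not active" (no number reported), so the starting point for compound 4 is already one of no reported activity. Compound 4 is therefore expected to give about 60000 nM, within a range from 20000 nM to 200000 nM, and it is expected that the assay may again report no number at all.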

Compound 4, half-maximal inhibitory concentration: 30000 nM
Compound 4: middle estimate off by 2.0-fold (0.30 log units), on the high side; measured number inside the range.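

In this assay, within the data shown here, compound 4 gives 30000 nM and compound 2 gives "not active" (no number reported) and so no step from compound 2 to compound 4 can be read. The compounds shown leave open whether benzyloxy in place of hydrogen on an aromatic carbon shifts the read-out at all on the core of compound 2. No measurement offered here accounts for this result.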